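Oxadiazole exchange, compound 1 to compound 4

This account rests on a few compounds, and the source may have more. Where it says the series, first, only, none or still open, it means among the compounds named here.

Measured compounds:
compound 1 `CCN(CC)S(=O)(=O)c1ccc(S(=O)(=O)N2CCC[C@@H](C(=O)N3CCN(c4nc(C(F)(F)F)no4)CC3)C2)cc1`, in a functional assay on MIA PaCa-2 cells (Homo sapiens) for inhibition, read by MTT assay, with a stated time of 3 days (a higher number here means a weaker inhibitor, a lower number a stronger inhibitor), compound 1 gives > 10000 nM, a limit of the assay and not a number.
compound 2 `CCN(CC)S(=O)(=O)c1ccc(S(=O)(=O)N2CCC[C@@H](C(=O)NC)C2)cc1`, compound 2 gives > 10000 nM, again only a limit.
compound 3 `CC(C)c1noc(N2CCN(C(=O)[C@@H]3CCCN(S(=O)(=O)c4ccc(S(=O)(=O)NC(C)(C)C)cc4)C3)CC2)n1`, compound 3 gives > 10000 nM, also a limit.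

Where compound 1 stands: at the limit, like everything else measured here. the limit of > 10000 nM in this assay, at which 3 of the 3 values shown sit — no compound in the set returns a number, so compound 1 cannot be placed above or below compound 2 or compound 3, and no order among the three can be drawn. Among the compounds with values here, no two measured compounds differ in a single place, so no measured step is available, and the three structures together give no hint that any part of the shared core carries activity in this assay.

Compound 4 `CCN(CC)S(=O)(=O)c1ccc(S(=O)(=O)N2CCC[C@@H](C(=O)N3CCN(c4nnc(C(C)C)o4)CC3)C2)cc1` arises from compound 1 by 5-isopropyl-1,3,4-oxadiazol-2-yl in place of 3-(trifluoromethyl)-1,2,4-oxadiazol-5-yl on an amine nitrogen in a ring. Within the data shown here, with compound 1 at the limit and no measured step to lean on, the expected step that the limit leaves unreadable from compound 1 to compound 4 in this assay is none beyond the scatter. Compound 4 is therefore estimated at 15000 nM, with a range from 5000 nM to 50000 nM, and most probably the assay will again report only a limit.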

Compound 4, half-maximal inhibitory concentration: > 10000 nM
Compound 4 was reported as a limit (the forecaster's own chance of this, stated with the estimate: 85%); the middle value lies beyond the limit too.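

No step can be read from compound 1 to compound 4, as both values are limits of the assay and not numbers, and no compound shown gives a number to compare: the limit of > 10000 nM in this assay, at which 4 of the 4 values shown sit.

The compounds shown leave open whether any change to the shared core or to the oxadiazole group can give a numerical value in this assay.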